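Removing tert-butoxycarbonyl from compound 3

A few compounds are considered here, and "the series" means these few. Any claim that something is new, unique, unknown or untested is made for them only; others in the source may bear on it.

In a functional assay on MCF7 cells (Homo sapiens) for inhibition, read by MTT assay, with a stated time of 72 h (a lower number here means a stronger inhibitor, a higher number a weaker inhibitor), compound 3 (`CC(C)[C@H](NC(=O)c1cc(Cl)ccc1OCCCNC(=O)OC(C)(C)C)C(=O)Nc1ccc([N+](=O)[O-])cc1Cl`) gives > 10000 nM as a limit and not a number. Compound 1 (`COC(=O)NCCOc1ccc(Cl)cc1C(=O)N[C@H](C(=O)Nc1ccc([N+](=O)[O-])cc1Cl)C(C)C`) gives > 10000 nM as a limit as well. Within the data shown here, compound 2 (`CC(C)COC(=O)NCCOc1ccc(Cl)cc1C(=O)N[C@H](C(=O)Nc1ccc([N+](=O)[O-])cc1Cl)C(C)C`) gives 10100 nM as the only true number so far. The set is therefore defined mainly by the limit of > 10000 nM in this assay, at which 2 of the 3 values shown sit, and offers little resolution.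

Compound 4 (`CC(C)[C@H](NC(=O)c1cc(Cl)ccc1OCCCN)C(=O)Nc1ccc([N+](=O)[O-])cc1Cl`) has hydrogen in place of tert-butoxycarbonyl on an amine nitrogen so that (tert-butoxycarbonyl)amino becomes amino.

Among the measured compounds shown here, three measured steps bear on this chain: a step that the limit leaves unreadable from compound 1 to compound 2 and a step that the two limits leave unreadable from compound 1 to compound 3 and a step that the limit leaves unreadable from compound 2 to compound 3 in the same assay. None has a readable size. None cuts the group back to amino, so none sets a size for this change.

For the measured compounds named here, the only numerical anchor is compound 2 at 10100 nM in this assay and a large move is not expected from it. The estimated change is an at least 1.2-fold lower number from compound 3 to compound 4 (0.09 log units; that floor lies within the scatter) and it is expected to be modest, with only a weak lean towards stronger inhibition. A further limit reading is also expected to be quite possible. For compound 4 the estimated value is 8000 nM with an expected range from 2000 nM to 20000 nM in this series.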

Compound 4, half-maximal inhibitory concentration: > 10000 nM
Compound 4 was reported as a limit; the forecaster's own chance of this, stated with the estimate: 45%; at least 1.2-fold (0.09 log units) between middle value and limit.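

In this assay compound 4 gives > 10000 nM, which is a limit and not a number. Its steps from compound 1, compound 2 and compound 3 therefore cannot be read. The compounds shown leave open whether hydrogen in place of tert-butoxycarbonyl changes inhibition at all, with the series resting on a single limit: the limit of > 10000 nM in this assay, at which 3 of the 4 values shown sit.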